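The source may report more compounds than this note shows. Statements on the series, on what has been measured and on what is new or still open speak of the compounds shown alone.

Measured compounds:

compound 1, `O=C1NCCN1c1ccc(S(=O)(=O)Nc2cccc(Br)c2)cc1`, 290 nM in a functional assay on MDA-MB-231 cells (Homo sapiens) for antiproliferative activity, read by sulforhodamine B assay, with a stated time of 48 h; a higher number here means a weaker inhibitor, a lower number a stronger inhibitor
compound 2, `COc1cc(NS(=O)(=O)c2ccc(N3CCNC3=O)cc2)cc(OC)c1OC`, 45 nM in this assay
compound 3, `COc1cccc(NS(=O)(=O)c2ccc(N3CCNC3=O)cc2)c1`, 730 nM in this assay

All three share the same core and differ only in the group carried on the sulfonamide nitrogen. Among these three numbers compound 1 stands second highest. Its nearest neighbour is compound 3, reached through a 2.5-fold higher number from compound 1 to compound 3 (0.40 log units; beyond the scatter), a modest step that lies beyond the usual scatter. The furthest is compound 2, whose value is well below that of compound 1 and is the lowest of the three.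

The unmeasured compound 4, `Cc1cc(C)cc(NS(=O)(=O)c2ccc(N3CCNC3=O)cc2)c1`, again changes only the group on the sulfonamide nitrogen: 3,5-dimethylphenyl in place of 3-bromophenyl on a sulfonamide nitrogen. Within the data shown here, only one measured step touches this position in a single change, the one from compound 1 to compound 3, which gave a 2.5-fold higher number from compound 1 to compound 3 (0.40 log units; beyond the scatter). Among the measured compounds shown here, no measured pair shows a methyl replacing a bromo, so that step is only a loose guide. On this basis a step in this assay that is small, possibly within the scatter, is expected, with a slight lean toward a higher number.

For compound 4 the estimated value is 420 nM, within a range from 150 nM to 1200 nM, meaning an expected step of a 1.4-fold higher number from compound 1 to compound 4 (0.16 log units; within the scatter).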

Compound 4, half-maximal inhibitory concentration: 1220 nM
For compound 4 the middle estimate is 2.9-fold (0.46 log units) below the measured one, outside the stated range (above it).
By their numbers in this assay, from the lowest: compound 2; then compound 1; then compounds 3 and 4 (each within the scatter of the next).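

The carbon-only 3,5-dimethylphenyl in place of 3-bromophenyl on a sulfonamide nitrogen gives, in this assay, a 4.2-fold higher number from compound 1 to compound 4 (0.62 log units; beyond the scatter), so a higher number at this position is not confined to the methoxy replacement seen earlier. Between the two bromine-free groups, 3,5-dimethylphenyl in place of 3-methoxyphenyl gives a 1.7-fold higher number from compound 3 to compound 4 (0.22 log units; within the scatter), so these two cannot be told apart here and both sit on the weaker side of compound 1, although compound 2, which also lacks bromine, goes against any simple rule that bromine is needed, with 45 nM in this assay. No measurement offered here gives a reason for these differences.

Because compound 4 carries two methyl groups while compound 1 carries one bromine, these compounds do not separate the kind of group from the number of groups, which a phenyl ring with a single methyl could help to do. From the compounds shown here alone, how this position would respond to a ring bearing an amine or a carboxylic acid, or to a saturated ring in place of the aromatic one, also remains open.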